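The source may report more compounds than this note shows. Statements on the series, on what has been measured and on what is new or still open speak of the compounds shown alone.

Compound 1 `CN(C)c1ccc(C2CC(c3ccccc3)=NN2C2=NC(=O)/C(=C3\C(=O)Nc4ccc(Br)cc43)S2)cc1` and compound 2 `CN(C)c1ccc(C2CC(c3ccccc3)=NN2C2=NC(=O)/C(=C3\C(=O)Nc4ccc(Cl)cc43)S2)cc1` share one core, while compound 3 `COc1ccc(-c2cc(-c3ccc(Cl)cc3)n(C3C(=O)Nc4ccc(Br)cc43)n2)cc1` and the unmeasured compound 4 `COc1ccc(-c2cc(-c3ccc(Cl)cc3)n(C3C(=O)Nc4ccc(Cl)cc43)n2)cc1` share another; how the two cores differ is not broken down here. In a functional assay on cells (Cancer cell lines, Homo sapiens) for cytotoxicity, read by sulforhodamine B assay, with a stated time of 48 h (on this read-out higher numbers stand for weaker inhibition of growth and lower numbers for stronger inhibition of growth), compound 1 gives 450 nM and compound 2 gives 430 nM, a change of a 1.0-fold lower number from compound 1 to compound 2 (0.02 log units; within the scatter). The same change, (chloro in place of bromo on an aromatic carbon), now links compound 3 to compound 4, as chloro in place of bromo on an aromatic carbon. Compound 3 gives 16700 nM in this assay, the highest of the three numbers. Because the earlier step of a 1.0-fold lower number from compound 1 to compound 2 (0.02 log units; within the scatter) stayed within the scatter, a similarly small step is expected here, a 1.0-fold lower number from compound 3 to compound 4 (0.02 log units; within the scatter). Compound 4 is therefore estimated at 16000 nM in this assay, most likely between 8000 nM and 33000 nM, with the measurement to follow.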

Compound 4, concentration for total growth inhibition: 14400 nM
Beside the measured number, compound 4's estimate is 1.1-fold (0.05 log units) above it; measured number inside the range.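

On the core of compound 3, chloro in place of bromo in this assay gives a 1.2-fold lower number from compound 3 to compound 4 (0.06 log units; within the scatter), so this swap again leaves the number within the usual scatter. Set beside the step on the core of compound 1, the change carries from one core to the other with no difference that can be told apart: the same change on two cores in this assay, a 1.0-fold lower number (0.02 log units; within the scatter) from compound 1 to compound 2 and a 1.2-fold lower number (0.06 log units; within the scatter) from compound 3 to compound 4, 1.1-fold (0.04 log units) apart, within the scatter of two such steps. Among the compounds shown here, this shows only that this one small swap has no measurable effect on these two cores in this assay; it does not show that a swap with a larger effect would carry over equally well.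

The compounds shown hold only bromo or chloro at this place on the aromatic ring. Going by these compounds, whether an amine, a nitrile or a carboxylic acid there would move the number on either core, and whether such a step would match between the cores, remains open.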